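Trimming an ethyl from the end of a long chain

The source may report more compounds than this note shows. Statements on the series, on what has been measured and on what is new or still open speak of the compounds shown alone.

Measured compounds:
- compound 1, `CC(C)c1cccc(C(C)C)c1NC(=O)Nc1nn[nH]n1`: > 10000 nM
- compound 2, `CCCCCCCCCCCCCc1nnc(NC(=O)Nc2c(C(C)C)cccc2C(C)C)s1`: 36 nM

Among the compounds with values here, in an assay on microsomes from intestine for inhibition of acyl-CoA:cholesterol acyltransferase (Oryctolagus cuniculus) (on this read-out lower numbers stand for stronger inhibition and higher numbers for weaker inhibition), compound 2 gives 36 nM, the only actual number among the values shown. Within the data shown here, compound 1 returns only a limit in this assay, > 10000 nM, as the line the limit of > 10000 nM in this assay, at which 1 of the 2 values shown sits, records, so no step between the two can be sized. Compound 3, `CCCCCCCCCCCc1nnc(NC(=O)Nc2c(C(C)C)cccc2C(C)C)s1`, differs from compound 2 by hydrogen in place of ethyl on a saturated chain carbon, ten or more bonds along the chain from an aromatic carbon. Among the measured compounds shown here, no step between measured compounds is available to gauge this change. The author expects a small shift at most, if anything towards slightly weaker inhibition, and no step beyond the usual scatter. Compound 3 is therefore estimated at 55 nM, within 20 nM to 160 nM, a step of a 1.5-fold higher number from compound 2 to compound 3 (0.18 log units; within the scatter) that is expected rather than known.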

Compound 3, half-maximal inhibitory concentration: 390 nM
The estimate for compound 3 lay 7.1-fold (0.85 log units) below the measured number; measured number above the stated range.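

In this assay, hydrogen in place of ethyl on a saturated chain carbon, ten or more bonds along the chain from an aromatic carbon, gives an 11-fold higher number from compound 2 to compound 3 (1.03 log units; beyond the scatter). Within the data shown here, this is the only step that can be sized here, and it shows that inhibition responds strongly to a change at this far stretch of the chain, with the rest of the structure left the same. Nothing shown accounts for the size of this step.

On these data alone, two chain lengths give a single step, so it remains open whether the number keeps rising with a shorter chain or falls with a longer chain. Also open, as far as these compounds go, is how a hydroxyl group, a carboxylic acid or an amine at the end of the chain would read in this assay.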